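The source may hold more compounds than are shown below. What is called first, only, known or untested is meant among the compounds shown, and "the series" means these compounds.

Measured so far in an ADME assay on the whole organism (Mus musculus, strain Swiss Webster) for pharmacokinetics, read by LC-MS, at a dose of 50 mg/kg by the oral route; a lower number here means less compound in the circulation, a higher number more compound in the circulation at the dose given:
- compound 1 `O=C(Nc1ccc(F)c(-c2nc3ncc(-c4ccc(F)c(F)c4)cc3[nH]2)c1)N1CCCC1`: 6670 nM
- compound 2 `O=C(Nc1ccc(F)c(-c2nc3ncc(-c4ccc(F)cc4)cc3[nH]2)c1)N1CCCC1`: 6270 nM
- compound 3 `O=C(Nc1ccc(F)c(-c2nc3ncc(-c4cc(F)cc(F)c4)cc3[nH]2)c1)N1CCCC1`: 4800 nM

Compound 1 sits together with the other two: the steps of a 1.1-fold lower number from compound 1 to compound 2 (0.03 log units; within the scatter) and a 1.4-fold lower number from compound 1 to compound 3 (0.14 log units; within the scatter) both lie within the scatter, as does a 1.3-fold lower number from compound 2 to compound 3 (0.12 log units; within the scatter). The three measured compounds differ only in the fluorinated phenyl group on the shared core, and every such exchange left the maximal plasma concentration essentially unchanged.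

Compound 4 `O=C(Nc1ccc(F)c(-c2nc3ncc(-c4ccccc4F)cc3[nH]2)c1)N1CCCC1` makes one more exchange of the same kind: 2-fluorophenyl in place of 3,4-difluorophenyl on an aromatic carbon. All three measured steps bear on this change, and none moved the number beyond the scatter, so no step beyond the scatter is expected in this assay either. Compound 4 is therefore expected to give about 5500 nM, between 2500 nM and 12000 nM, which is expected to amount to a 1.2-fold lower number from compound 1 to compound 4 (0.08 log units; within the scatter).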

Compound 4, maximal plasma concentration: 2230 nM
The estimate for compound 4 lay 2.5-fold (0.39 log units) above the measured number; the measured number lies below the stated range.
By their numbers in this assay, from the lowest: compound 4; then compounds 3, 2 and 1 (each within the scatter of the next).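

In this assay, this position proves sensitive to which fluorinated phenyl group it carries, as 2-fluorophenyl gives a 3.0-fold lower number from compound 1 to compound 4 (0.48 log units; beyond the scatter), a 2.8-fold lower number from compound 2 to compound 4 (0.45 log units; beyond the scatter) and a 2.2-fold lower number from compound 3 to compound 4 (0.33 log units; beyond the scatter). These steps are modest, yet 3,4-difluorophenyl, 4-fluorophenyl and 3,5-difluorophenyl stayed within the scatter of one another, so among these four groups only 2-fluorophenyl stands apart. Nothing available explains this difference. As far as these compounds go, whether other groups in this place, such as unsubstituted phenyl, 2-chlorophenyl or 2-methylphenyl, would also lower the number remains open.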